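Shifting the aryl group on the piperazine of a thiophene scaffold

The compounds below may be only part of what the source reports. "The series", "measured", "known", "first", "only" and "open" are said of these compounds alone.

Of the compounds shown here, three sharing one core have been measured in a functional assay on CHO cells with adenosine receptor A1 (Homo sapiens) as the target, read by cAMP accumulation and immunoassay, with a stated time of 6 min, tested at 1 uM; on this read-out higher numbers stand for a weaker effect at the one concentration tested and lower numbers for a stronger effect. Compound 1 `Nc1scc(CN2CCN(c3ccc(Cl)cc3F)CC2)c1C(=O)c1ccc(Cl)cc1` gives -57% in this assay. Compound 3 `Nc1scc(CN2CCC(c3ccc(Cl)cc3)CC2)c1C(=O)c1ccc(Cl)cc1` gives -24%. Compound 2 `Nc1scc(CN2CCN(c3ccc([N+](=O)[O-])cc3)CC2)c1C(=O)c1ccc(Cl)cc1` gives -8.3%, the highest of the three numbers, standing beyond the scatter from both compound 3 and compound 1.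

Among the compounds with values here, the only single-point step among the measured compounds runs a number 48.7 percentage points higher from compound 1 to compound 2 (beyond the scatter), a large move toward the weaker end. The next compound, compound 4 `Nc1scc(CN2CCN(c3ccccc3F)CC2)c1C(=O)c1ccc(Cl)cc1`, differs from compound 2 as follows: 2-fluorophenyl in place of 4-nitrophenyl on an amine nitrogen in a ring. Within the data shown here, the group that leaves carries two hydrogen-bond acceptors and the group that enters carries none, so the change partly reverses the single measured step, although the entering group lacks the chlorine that compound 1 bears.

Compound 4 is therefore expected to move back toward the stronger end, with an estimated step of a number 26.7 percentage points lower from compound 2 to compound 4 (beyond the scatter). Among the measured compounds shown here, the estimate for compound 4 is -35%, within a range from -62% to -8%, reflecting that only one step bears on it.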

Compound 4, a percentage reported as activity, at one concentration (the size of the read-out at that concentration, not a potency): -9.2%
Compound 4: middle estimate off by 25.8 percentage points, on the low side, and the stated range covers the measured number.
By their numbers in this assay, from the lowest: compound 1; then compound 3; then compounds 4 and 2 (each within the scatter of the next).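

In this assay, 2-fluorophenyl in place of 4-nitrophenyl on the amine nitrogen gives a number 0.9 percentage points lower from compound 2 to compound 4 (within the scatter), so these two aryl groups cannot be told apart here despite their different hydrogen-bond acceptor counts. Within the data shown here, the sharper change is hydrogen in place of chloro on an aromatic carbon, which gives a number 47.8 percentage points higher from compound 1 to compound 4 (beyond the scatter), so the one chloro of compound 1 separates it by a large margin from compound 4, which otherwise has the same structure. The large step from the earlier comparison therefore need not depend on the 4-nitrophenyl group, and nothing available explains why this chloro matters so much. On these data alone, it remains open whether bromo or methoxy in place of that chloro would keep the number of compound 1. As far as these compounds go, it is also open whether chloro would have the same effect on an aryl group without the fluoro.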